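The source may report more compounds than this note shows. Statements on the series, on what has been measured and on what is new or still open speak of the compounds shown alone.

Compound 1 `CCCCN1C(=O)NC(=O)/C1=C\c1ccccc1`: 6.8%
Compound 2 `CCCCN1C(=O)NC(=O)/C1=C/c1ccccc1`: 18%

In a functional assay on A549 cells (Homo sapiens) for antiproliferative activity, read by trypan blue exclusion, with a stated time of 72 h, tested at 20 uM (on this read-out lower numbers stand for less inhibition and higher numbers for more inhibition at the one concentration tested (going by the name of the read-out)), compound 2 stands highest of the two numbers, its nearest neighbour being compound 1; the step of a number 11.2 percentage points higher from compound 1 to compound 2 (beyond the scatter) goes with the fact that compounds 1 and 2 differ only in the configuration as drawn, the drawn geometry of the double bond alone.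

Compound 3 `CN1C(=O)NC(=O)/C1=C/c1ccccc1` differs from compound 2 in one place: hydrogen in place of propyl on a saturated chain carbon bound to an amide-type nitrogen in a ring. No measured step touches this chain, since the only step shown changes configuration rather than the group on the ring nitrogen, so nothing shown speaks to its size. The expected step is therefore none beyond the scatter: a number 3 percentage points lower from compound 2 to compound 3 (within the scatter). Compound 3 is estimated at 15%, within 2% to 35%.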

Compound 3, a percentage reported as inhibition, at one concentration (the size of the read-out at that concentration, not a potency): 16%
Estimate against measurement, compound 3: 1 percentage points below, within the range that was stated.
By their numbers in this assay, from the lowest: compounds 1, 3 and 2 (each within the scatter of the next, the first and the last beyond it).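

In this assay, going from butyl to methyl on the amide-type nitrogen in a ring gives a number 2 percentage points lower from compound 2 to compound 3 (within the scatter). With the double bond drawn Z, this chain can therefore lose its propyl part without a step that stands out from the scatter. Nothing available explains this result.

Open, from the compounds shown here alone, is whether a longer chain, such as octyl, or a chain ending in an amine or a carboxylic acid would read differently at this nitrogen. Also open, going by these compounds, is how methyl behaves with the double bond drawn E.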